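Chloro to methyl on the aryl group of the hydroxamate series

The compounds below may be only part of what the source reports. "The series", "measured", "known", "first", "only" and "open" are said of these compounds alone.

Compound 1 `O=C(CCC1=CCN(CCCc2ccc(Cl)cc2)C1=O)NO`, compound 2 `O=C(CCC1=CCN(Cc2ccc(Br)cc2F)C1=O)NO` and compound 3 `O=C(CCC1=CCN(Cc2cc(C(F)(F)F)cc(C(F)(F)F)c2)C1=O)NO` share one core and differ only in the group carried on the ring nitrogen. In a functional assay on NCI-H23 cells (Homo sapiens) for inhibition, read by sulforhodamine B assay (on this read-out lower numbers stand for stronger inhibition of growth and higher numbers for weaker inhibition of growth), compound 1 gives 2520 nM, compound 2 gives 2500 nM and compound 3 gives 2500 nM. Compound 1 holds the highest of the three numbers, yet its nearest neighbour, compound 2, and its furthest, compound 3, both lie within the usual scatter of it, so the three cannot be told apart on these numbers.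

Compound 4 `Cc1ccc(CCCN2CC=C(CCC(=O)NO)C2=O)cc1` is not yet measured in this assay. Against compound 1 the change is methyl in place of chloro on an aromatic carbon. Among the measured compounds shown here, no step between measured compounds covers this change. Among the three measured compounds, rather different groups on the aryl ring leave the values within the scatter of one another; compound 1, compound 2 and compound 3 give no sign of sensitivity to that substituent. The step from compound 1 to compound 4 is therefore expected to stay within the scatter, in no clear direction: a 1.1-fold higher number from compound 1 to compound 4 (0.03 log units; within the scatter). For compound 4 the estimate in this assay is 2700 nM, with a range from 1200 nM to 6000 nM.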

Compound 4, concentration for 50% growth inhibition: 2520 nM
Compound 4: the middle estimate sits 1.1-fold (0.03 log units) above what was measured; the measured number falls inside the stated range.
By their numbers in this assay, from the lowest: compounds 2, 3, 1 and 4 (each within the scatter of the next).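

In this assay, methyl in place of chloro on an aromatic carbon, para to a large group, gives no change at the digits printed from compound 1 to compound 4 (within the scatter) in this matched pair. Compounds 1, 2 and 3 differ from one another in more than one feature of the group on the ring nitrogen, whereas this pair isolates a single substituent at a single position. Here, 4-chlorophenyl and 4-methylphenyl cannot be told apart on this read-out, and no measurement bearing on why is available.

Still open, as far as these compounds go, is whether this position would read the same with an amine, a carboxylic acid or a methoxy group in place of chloro or methyl. The compounds shown also leave open what a carboxylic acid in place of the hydroxamate would give on the shared core.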